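Small change, small shift expected in clearance

The compounds below may be only part of what the source reports. "The series", "measured", "known", "first", "only" and "open" are said of these compounds alone.

Values so far in an ADME assay on microsomes from liver (Homo sapiens) for metabolic stability; a lower number here means slower removal, a higher number faster removal of the compound
compound 1 `Cc1ccc(C(=O)Nc2cn3ncnc3c(O[C@@H]3CCN(C(=O)CC(C(F)(F)F)C(F)(F)F)[C@@H](C)C3)c2C)cn1` gives 28 mL.min-1.g-1 as a measured number
compound 2 `Cc1ccc(C(=O)Nc2cn3ncnc3c(CN3CCN(C(=O)CCC(F)(F)F)[C@@H](C)C3)c2C)cn1` gives < 10 mL.min-1.g-1 as a limit of the assay

Compound 2 stands at the limit of < 10 mL.min-1.g-1 in this assay, at which 1 of the 2 values shown sits, and so has a limit, not a number. Compound 3 `Cc1ccc(C(=O)Nc2cn3ncnc3c(CN3CCN(C(=O)C4CCC(F)(F)C4)[C@@H](C)C3)c2C)cn1` is not yet measured. It carries 3,3-difluorocyclopentyl in place of 3,3,3-trifluoropropyl on a carbonyl carbon and is otherwise the same as compound 2. Among the measured compounds shown here, no measured step shows what this swap does, so only a small rise is expected, close to the scatter. The estimated move an at least 1.2-fold higher number from compound 2 to compound 3 (0.07 log units; that floor lies within the scatter) is expected to be modest, and the result may also come back as a limit. For compound 3 the estimated value is 12 mL.min-1.g-1 within an expected range of 7 mL.min-1.g-1 to 24 mL.min-1.g-1 in this assay terms.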

Compound 3, intrinsic clearance in microsomes: < 10 mL.min-1.g-1
Compound 3 was reported as a limit; the forecaster's own chance of this, stated with the estimate: 40%; middle value at least 1.2-fold (0.07 log units) from the limit.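

Compound 2 and compound 3 both come back in this assay as a limit of the assay, not a number, so no step between them can be read: the limit of < 10 mL.min-1.g-1 in this assay, at which 2 of the 3 values shown sit.

As far as these compounds go, the actual clearance of each compound stays open, and so does whether 3,3-difluorocyclopentyl in place of 3,3,3-trifluoropropyl changes it at all.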